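The source may report more compounds than this note shows. Statements on the series, on what has been measured and on what is new or still open speak of the compounds shown alone.

Working notes on the series. In a functional assay on Huh-5-2 cells (Homo sapiens), read by MTT assay (on this read-out lower numbers stand for higher toxicity in this test and higher numbers for lower toxicity in this test), compound 1 `N#Cc1ccc(-c2ccc(Cl)cc2)c(COc2ccc(-c3nc4cc(C(=O)O)ccc4n3C3CCCCC3)cc2)c1` gives 23000 nM, compound 2 `CNC(=O)c1ccc(-c2ccc(Cl)cc2)c(COc2ccc(-c3nc4cc(C(=O)O)ccc4n3C3CCCCC3)cc2)c1` gives 25000 nM and compound 3 `O=C(O)c1ccc2c(c1)nc(-c1ccc(OCc3cc(C(=O)N4CCCCC4)ccc3-c3ccc(Cl)cc3)cc1F)n2C1CCCCC1` gives 24000 nM. Compound 3 therefore lies within the scatter of both other compounds, and the three numbers support no ranking.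

The next step leads to compound 4 `CC(=O)N(C)c1ccc(-c2ccc(Cl)cc2)c(COc2ccc(-c3nc4cc(C(=O)O)ccc4n3C3CCCCC3)c(F)c2)c1`, which carries acetyl(methyl)amino in place of (piperidin-1-yl)carbonyl on an aromatic carbon, para to a 4-chlorophenyl group: acetyl(methyl)amino in place of (piperidin-1-yl)carbonyl on an aromatic carbon.

Among the compounds with values here, no measured step covers this exact exchange. The closest evidence is a 1.1-fold higher number from compound 1 to compound 2 (0.04 log units; within the scatter), where methylcarbamoyl takes the place of cyano on the same aromatic carbon, and that step stays within the scatter. Compound 3, with its (piperidin-1-yl)carbonyl group, gives 24000 nM, again within the scatter of the other two. Three different groups at this carbon thus leave the number in this assay unmoved, although three compounds are a thin basis and none of them carries acetyl(methyl)amino.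

No step beyond the scatter is expected, and the estimate amounts to no change at the digits printed from compound 3 to compound 4 (within the scatter). For compound 4 the estimated value is 24000 nM, with an expected range of 13000 nM to 42000 nM.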

Compound 4, half-maximal cytotoxic concentration: 26000 nM
Estimate against measurement, compound 4: 1.1-fold (0.03 log units) below; the measured number falls inside the stated range.
By their numbers in this assay, from the lowest: compounds 1, 3, 2 and 4 (each within the scatter of the next).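

In this assay, the exchange gives a 1.1-fold higher number from compound 3 to compound 4 (0.03 log units; within the scatter), so the number does not respond when a (piperidin-1-yl)carbonyl group of 8 heavy atoms with a six-membered non-aromatic ring gives way to an acetyl(methyl)amino group of 5 heavy atoms with no ring. The earlier compounds shown here showed only that nitrile, methylcarbamoyl and (piperidin-1-yl)carbonyl groups gave numbers within the scatter of one another; this step adds that neither the ring nor those 3 additional heavy atoms are needed for the number seen at this carbon, para to a 4-chlorophenyl group, at least in the fluorine-bearing pair of compound 3 and compound 4. Nothing available explains this lack of response, and it remains an observation about one pair of compounds.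

Going by these compounds, it remains open whether a primary amine or a carboxylic acid on this aromatic carbon would give a step beyond the scatter. The fluorine shared by compound 3 and compound 4 also cannot be assessed, as no compound shown differs from either of them by that atom alone.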